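A dichlorophenyl sulfonyl variant of a hydrazide series

The compounds below may be only part of what the source reports. "The series", "measured", "known", "first", "only" and "open" are said of these compounds alone.

Compound 1 `CC(=O)Nc1ccc(S(=O)(=O)NNC(=O)c2cccnc2Nc2ccc(Cl)cc2)cc1` and compound 2 `O=C(NNS(=O)(=O)c1ccc(F)cc1)c1cccnc1Nc1ccc(Cl)cc1Cl` share one core and were tested in a functional assay on TK-10 cells (Homo sapiens) for antiproliferative activity; on this read-out higher numbers stand for lower toxicity in this test and lower numbers for higher toxicity in this test. Compound 1 reaches only the limit of > 100000 nM in this assay, not a number. Compound 2 likewise stops at the limit of > 100000 nM. Compound 1 stands where both shown values sit, (the limit of > 100000 nM in this assay, at which 2 of the 2 values shown sit). Compound 3 `O=C(NNS(=O)(=O)c1ccc(Cl)cc1Cl)c1cccnc1Nc1ccc(Cl)cc1` differs from compound 1 by 2,4-dichlorophenyl in place of 4-acetamidophenyl on a sulfonyl sulfur. Among the compounds with values here, no measured single-place step exists, so for the step from compound 1 to compound 3 in this assay no direction beyond the scatter is expected. Compound 3 is estimated at 100000 nM, from 30000 nM to 300000 nM, most likely again reported as a limit. The expected step is a number no higher from compound 1 to compound 3 (the limit leaves the size open).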

Compound 3, concentration lethal to 50% of the cells: > 100000 nM
Compound 3 ended at the assay's limit; the forecaster's own chance of this, stated with the estimate: 80%; the middle value sits exactly at the limit.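

Compound 1 and compound 3 both end at a limit in this assay, not at a number, so no step between them can be read: the limit of > 100000 nM in this assay, at which 3 of the 3 values shown sit.

The compounds shown leave open what 2,4-dichlorophenyl in place of 4-acetamidophenyl on a sulfonyl sulfur does to this read-out; none of them gives a number.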